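The source may hold more compounds than are shown below. What is called first, only, known or untested is meant among the compounds shown, and "the series" means these compounds.

In an ADME assay on L6 cells (Rattus norvegicus) for cytotoxicity, read by resazurin assay, with a stated time of 72 h (a higher number here means a weaker inhibitor, a lower number a stronger inhibitor), compound 2 `O=C(CN1CCCCC1)OC1CC2(N3CCCCC3)CC(c3ccccc3)C1C(c1ccccc1)C2` gives 60400 nM and compound 1 `CN(C)C12CC(OC(=O)CN3CCCC3)C(C(c3ccccc3)C1)C(c1ccccc1)C2` gives 32700 nM and these two numbers lie within the usual scatter of each other. Compound 3 `CN(C)C12CC(OC(=O)CN3CCCCC3)C(C(c3ccccc3)C1)C(c1ccccc1)C2` differs from compound 2 in one place, with dimethylamino in place of piperidin-1-yl on a saturated ring carbon and nothing else changed. For the measured compounds named here, no measured pair shows this change alone, but compound 1 also carries dimethylamino and stands at 32700 nM in this assay and so no large shift is expected. The estimated step of a 1.4-fold lower number from compound 2 to compound 3 (0.16 log units; within the scatter) is expected to stay within the scatter. Compound 3 is expected at 42000 nM with a range of 20000 nM to 85000 nM in this estimate.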

Compound 3, half-maximal inhibitory concentration: 29300 nM
Estimate against measurement, compound 3: 1.4-fold (0.16 log units) above; measured number inside the range.
By their numbers in this assay, from the lowest: compounds 3, 1 and 2 (each within the scatter of the next, the first and the last beyond it).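

In this assay, for the compounds shown here, dimethylamino in place of piperidin-1-yl on the saturated ring carbon gives a 2.1-fold lower number from compound 2 to compound 3 (0.31 log units; beyond the scatter) and so provides the first modest step at this position. On the saturated chain carbon bound to a carbonyl carbon, piperidin-1-yl in place of pyrrolidin-1-yl gives a 1.1-fold lower number from compound 1 to compound 3 (0.05 log units; within the scatter) and does not separate the two compounds. Nothing measured here explains the step at the ring carbon. The compounds shown leave open how a primary amine or a morpholin-4-yl group on that ring carbon would compare.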